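Swapping a Pentylphenyl for a Hydroxyphenyl on a Triazole

This account rests on a few compounds, and the source may have more. Where it says the series, first, only, none or still open, it means among the compounds named here.

The shared core here is a lactone bearing two benzyloxy groups, joined through a short linker to a five-membered aromatic ring with three nitrogens. Compound 1 `CCCCCc1ccc(-c2cn(C/C=C3\OC(=O)C(OCc4ccccc4)=C3OCc3ccccc3)nn2)cc1` carries a 4-pentylphenyl on that ring. In a functional assay on A549 cells (Homo sapiens) for antiproliferative activity, read by MTT assay, with a stated time of 72 h (on this read-out higher numbers stand for weaker inhibition and lower numbers for stronger inhibition), compound 1 gives > 100000 nM, which is a limit of the assay and not a number. Compound 1 therefore stands at the limit of > 100000 nM in this assay, at which 1 of the 2 values shown sits. Compound 2 `O=C1O[C@H]([C@@H](O)Cn2cc(CNS(=O)(=O)c3ccc(F)cc3)nn2)C(OCc2ccccc2)=C1OCc1ccccc1` belongs to the same study but has a different linker and a sulfonamide arm, and in this assay compound 2 gives 22500 nM. Compound 3 `O=C1O/C(=C\Cn2cc(-c3cccc(O)c3)nn2)C(OCc2ccccc2)=C1OCc1ccccc1` is the unmeasured partner of compound 1: the change is 3-hydroxyphenyl in place of 4-pentylphenyl on an aromatic carbon. Among the compounds with values here, no measured pair shows this change, so the size of the step is open, and a limit on one side leaves only the direction to guess. The expectation is a modest gain, an at least 2.0-fold lower number from compound 1 to compound 3 (0.30 log units; that floor lies within the scatter). Compound 3 is estimated at 50000 nM, with a range from 15000 nM to 200000 nM.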

Compound 3, half-maximal inhibitory concentration: 23300 nM
Beside the measured number, compound 3's estimate is 2.1-fold (0.33 log units) above it; the measured number falls inside the stated range.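

In this assay, within the data shown here, the change on this aromatic carbon of the ring with three nitrogens gives the first readable step at this position: an at least 4.2-fold lower number from compound 1 to compound 3 (0.63 log units; beyond the scatter). Compound 3 gives a measured 23300 nM, so this place on the shared core can carry an aryl group that produces a real number in the cell test, and the 3-hydroxyphenyl does so where the 4-pentylphenyl does not. The value of compound 1 is a limit and not a number, so the step has a floor but no known size, and the true gap could be larger: the limit of > 100000 nM in this assay, at which 1 of the 3 values shown sits.

The single swap changes several things at once, since the pentyl chain leaves, a hydroxyl enters, and the substituent sits at a different place on the phenyl ring, and the compounds shown cannot tell which of these matters. Still open, going by these compounds, is how a plain phenyl, a 4-hydroxyphenyl or a 3-methoxyphenyl would read at this same carbon, any of which would begin to pull those changes apart.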